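Methylsulfanyl to ethylsulfanyl: a small step on compound 3

This account rests on a few compounds, and the source may have more. Where it says the series, first, only, none or still open, it means among the compounds named here.

Measured in a functional assay on HeLa cells (Homo sapiens) for antiproliferative activity, read by CCK-8 assay, with a stated time of 72 h (on this read-out higher numbers stand for weaker inhibition and lower numbers for stronger inhibition), so far:
compound 1 `COc1ccc(-c2cncnc2-c2cc(OC)c(OC)c(OC)c2)cc1O` (280 nM)
compound 2 `COc1ccc(-c2cncnc2-c2cc(OC)c(OC)c(OC)c2)cc1F` (500 nM)
compound 3 `COc1cc(-c2ncncc2-c2ccc(SC)cc2)cc(OC)c1OC` (220 nM)

The steps of a 1.3-fold lower number from compound 1 to compound 3 (0.10 log units; within the scatter) and a 2.3-fold lower number from compound 2 to compound 3 (0.36 log units; beyond the scatter) place compound 3 within the scatter of compound 1 and beyond it from compound 2. Compound 4 `CCSc1ccc(-c2cncnc2-c2cc(OC)c(OC)c(OC)c2)cc1` differs from compound 3 by methyl in place of hydrogen on a saturated chain carbon bound to a sulfur on the chain, turning methylsulfanyl into ethylsulfanyl. Within the data shown here, no measured step alters this chain. The nearest evidence is those exchanges of the whole phenyl group and a 1.8-fold higher number from compound 1 to compound 2 (0.25 log units; within the scatter) on the phenyl group, all small. Starting from compound 3 at 220 nM in this series, no change beyond the scatter is expected in this assay for compound 4. The expected step is a 1.3-fold higher number from compound 3 to compound 4 (0.10 log units; within the scatter) and stays within the scatter. Compound 4 is estimated at 280 nM within a range from 110 nM to 700 nM for now.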

Compound 4, half-maximal inhibitory concentration: 370 nM
Beside the measured number, compound 4's estimate is 1.3-fold (0.12 log units) below it, and the stated range covers the measured number.
By their numbers in this assay, from the lowest: compounds 3, 1, 4 and 2 (each within the scatter of the next, the first and the last beyond it).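

In this assay, among these compounds, the first change on the chain itself, methylsulfanyl to ethylsulfanyl, gives a step within the scatter (a 1.7-fold higher number from compound 3 to compound 4 (0.23 log units; within the scatter)). The added methyl on the saturated chain carbon bound to a sulfur therefore cannot be told apart from hydrogen here. The exchanges of the whole phenyl group (a 1.4-fold lower number from compound 2 to compound 4 (0.13 log units; within the scatter); a 1.3-fold higher number from compound 1 to compound 4 (0.12 log units; within the scatter)) also stay within the scatter, and no evidence bears on the origin of any of these steps.

On these data alone, whether a longer chain such as butylsulfanyl, or an amine at the end of the chain, would give a step beyond the scatter remains open.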